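From 3-methylthiophen-2-yl to 4-methoxyphenyl on compound 3

This account rests on a few compounds, and the source may have more. Where it says the series, first, only, none or still open, it means among the compounds named here.

In a functional assay on DU-145 cells (Homo sapiens) for inhibition, read by trypan blue exclusion, with a stated time of 96 h (on this read-out higher numbers stand for weaker inhibition of growth and lower numbers for stronger inhibition of growth), compound 1 `O=C(/C(=C\c1ccc(Br)cc1)SCc1ccc(Cl)cc1)c1ccc(Br)cc1` gives 1000 nM and compound 2 `COc1ccc(/C=C(/SCc2ccc(F)cc2)C(=O)c2ccc(Cl)cc2)c(OC)c1OC` gives 10000 nM as its growth-inhibition value. In this assay compound 3 `Cc1ccc(S/C(=C/c2sccc2C)C(=O)c2ccc(Br)cc2)cc1` gives 50000 nM and so has the highest number of the three, beyond the usual scatter from both others, which makes it the weakest growth inhibitor of this small set.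

Compound 4 `COc1ccc(/C=C(/Sc2ccc(C)cc2)C(=O)c2ccc(Br)cc2)cc1` differs from compound 3 in one place, with 4-methoxyphenyl in place of 3-methylthiophen-2-yl on a double-bonded chain carbon bound to a double-bonded chain carbon. Among the measured compounds shown here, no measured pair shows this swap alone. Compound 1 (1000 nM) and compound 2 (10000 nM) both hold a six-membered aromatic ring of carbon only at that place and both have lower numbers than compound 3 (50000 nM), though they also differ elsewhere, so this is thin evidence.

In this assay a moderate move toward stronger inhibition of growth is expected, and the estimated step is wide in its uncertainty (a 10-fold lower number from compound 3 to compound 4 (1.00 log units; beyond the scatter)). Compound 4 is expected to give about 5000 nM with an estimated range of 800 nM to 30000 nM on this read-out.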

Compound 4, concentration for 50% growth inhibition: 50000 nM
Compound 4: the middle estimate sits 10-fold (1.00 log units) below what was measured; the measured number lies above the stated range.
By their numbers in this assay, from the lowest: compound 1; then compound 2; then compounds 3 and 4 (each within the scatter of the next).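

In this assay, putting 4-methoxyphenyl in place of 3-methylthiophen-2-yl on a double-bonded chain carbon bound to a double-bonded chain carbon gives no change at the digits printed from compound 3 to compound 4 (within the scatter). Among the compounds shown here, this is the first direct reading of this position, and it shows that with the rest of compound 3 held fixed, a six-membered aromatic ring of carbon only at this place is not enough on its own to strengthen growth inhibition. The data offer no measured explanation for why these two different rings give the same reading.

Still open, as far as these compounds go, is whether a group of another kind at this place, such as an amine or a carboxylic acid, would move the number. From the compounds shown here alone, it is also open whether this same ring swap would leave the number unchanged on a molecule that differs from compound 3 elsewhere.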